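The source may report more compounds than this note shows. Statements on the series, on what has been measured and on what is new or still open speak of the compounds shown alone.

For the measured compounds named here, in a functional assay on HL-60 cells (Homo sapiens) for antiproliferative activity, read by MTT assay (on this read-out lower numbers stand for stronger inhibition and higher numbers for weaker inhibition), compound 1 (`c1ccc(COC[C@H]2OCC[C@@H](OCc3ccccc3)[C@@H]2OCc2ccccc2)cc1`) gives 39300 nM and compound 3 (`CC(C)C[C@H]1O[C@H](COCc2ccccc2)[C@@H](OCc2ccccc2)[C@H](OCc2ccccc2)[C@H]1O`) gives 13900 nM as the lowest number so far, lower than that of compound 1 by more than the usual scatter. Compound 2 (`C#CC[C@@H]1O[C@H](COCc2ccccc2)[C@@H](OCc2ccccc2)[C@H](OCc2ccccc2)[C@H]1O`) is reported as "not active" (no number reported) without a number. Compound 4 (`O[C@H]1CO[C@H](COCc2ccccc2)[C@@H](OCc2ccccc2)[C@@H]1OCc1ccccc1`) has not been measured yet. Moving to it from compound 3 is the change hydrogen in place of isobutyl on a saturated ring carbon. Going by the values given here, no measured pair shows this change alone. Compound 1, which also has no isobutyl, gives 39300 nM as its number, so weaker inhibition is expected. The estimated step is a 2.9-fold higher number from compound 3 to compound 4 (0.46 log units; beyond the scatter) toward a higher number. The estimated value for compound 4 is 40000 nM within 15000 nM to 100000 nM as the likely span.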

Compound 4, half-maximal inhibitory concentration: "not active" (no number reported)
For compound 4 the study gives words and no number; no gap can be computed for the estimate.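

For the compounds shown here, compound 4 is reported in words only, so no step from compound 3 to compound 4 can be read, and no evidence at hand bears on this result. From the compounds shown here alone, how far the isobutyl group alone moves the number in this assay stays open.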